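The compounds below may be only part of what the source reports. "The series", "measured", "known", "first", "only" and "open" are said of these compounds alone.

In a functional assay on HepG2 cells (Homo sapiens) for antiproliferative activity, read by MTT assay (on this read-out higher numbers stand for weaker inhibition and lower numbers for stronger inhibition), compound 1 `CC(=O)c1ccc(-n2cc(COc3ccc(/C=C/C(=O)c4cc5c(cc4O)OC(C)(C)CC5)cc3)nn2)cc1` is recorded as "not active" (no number reported) with no number given. Among the measured compounds shown here, compound 2 `COc1ccc(-n2cc(COc3ccc(/C=C/C(=O)c4ccc5c(c4O)CCC(C)(C)O5)cc3)nn2)c([N+](=O)[O-])c1` gives 120000 nM and so stands within the scatter of compound 3 `CCCCCCCCn1cc(COc2ccc(/C=C/C(=O)c3cc4c(cc3O)OC(C)(C)CC4)cc2)nn1` at 127000 nM and these are the only two numbers available. Compound 4 `CCCCCCCCn1cc(COc2ccc(/C=C/C(=O)c3ccc4c(c3O)CCC(C)(C)O4)cc2)nn1` keeps the core of compound 2 and changes one group, with octyl in place of 4-methoxy-2-nitrophenyl on an aromatic nitrogen. For the measured compounds named here, the counted difference is octyl in place of 4-methoxy-2-nitrophenyl on an aromatic nitrogen and no measured pair isolates this exchange. Compound 3 also carries octyl, on a core that differs from that of compound 2, and the value of compound 3 at 127000 nM is the main support for expecting no step beyond the scatter in this assay here. The expected step is a 1.0-fold higher number from compound 2 to compound 4 (0.02 log units; within the scatter) and it is estimated to stay within the scatter. For compound 4 the estimated value is 125000 nM with an expected range from 55000 nM to 280000 nM in this test.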

Compound 4, half-maximal inhibitory concentration: 74100 nM
Compound 4: middle estimate off by 1.7-fold (0.23 log units), on the high side; the range from low to high includes it.
By their numbers in this assay, from the lowest: compounds 4, 2 and 3 (each within the scatter of the next).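

Among the compounds shown here, with this pair, the exchange of 4-methoxy-2-nitrophenyl for octyl on an aromatic nitrogen of the five-membered ring can be read directly for the first time: in this assay it gives a 1.6-fold lower number from compound 2 to compound 4 (0.21 log units; within the scatter). On the core of compound 2, then, a substituent with one six-membered aromatic ring and hydrogen-bond acceptors and an octyl chain with neither are not told apart at this position by this read-out. Nothing available here offers an explanation for this result.

As far as these compounds go, whether an amine, a carboxylic acid or a shorter chain such as butyl on this nitrogen would move the number beyond the scatter remains open. So does whether the same exchange would also stay within the scatter on the core of compound 3.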